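A few compounds are considered here, and "the series" means these few. Any claim that something is new, unique, unknown or untested is made for them only; others in the source may bear on it.

The series varies one group on an aromatic carbon of a shared core. In a functional assay on CCRF-CEM cells (Homo sapiens), read by MTT assay, with a stated time of 72 h (a lower number here means a stronger inhibitor, a higher number a weaker inhibitor), compound 1 `Cc1ncnc2c1c(-c1ccoc1)cn2[C@@H]1O[C@H](CO)[C@@H](O)[C@H]1O` gives > 20000 nM, and this value is a limit of the assay, not a number. Compound 2 `Cc1ncnc2c1c(-c1ccsc1)cn2[C@@H]1O[C@H](CO)[C@@H](O)[C@H]1O` gives 11200 nM and compound 3 `C#Cc1cn([C@@H]2O[C@H](CO)[C@@H](O)[C@H]2O)c2ncnc(C)c12` gives 5600 nM. Those two values lie within the scatter of each other, so they cannot be ranked, and compound 3 stands level with compound 2 on the numbers available.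

Compound 4 `Cc1ncnc2c1c(I)cn2[C@@H]1O[C@H](CO)[C@@H](O)[C@H]1O` is the next case: iodo in place of ethynyl on an aromatic carbon. Going by the values given here, no measured step involves iodo, so the evidence is indirect. The thiophen-3-yl to ethynyl change, a 2.0-fold lower number from compound 2 to compound 3 (0.30 log units; within the scatter), stays within the scatter, as does the floor of the furan-3-yl to thiophen-3-yl change, an at least 1.7-fold lower number from compound 1 to compound 2 (0.25 log units; that floor lies within the scatter). Only an at least 3.5-fold lower number from compound 1 to compound 3 (0.55 log units; beyond the scatter) goes beyond the scatter, and it starts from the limit of a ring-bearing compound. Neither ethynyl nor iodo contains a ring, so that step offers little guidance here, and no clear shift in this assay is expected in either direction. The estimated step is a 1.1-fold higher number from compound 3 to compound 4 (0.03 log units; within the scatter), which is expected to remain within the scatter. For compound 4 the estimate is 6000 nM, with an expected range from 1800 nM to 20000 nM.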

Compound 4, half-maximal inhibitory concentration: 5480 nM
The estimate for compound 4 lay 1.1-fold (0.04 log units) above the measured number, and the stated range covers the measured number.
By their numbers in this assay, from the lowest: compounds 4, 3 and 2 (each within the scatter of the next, the first and the last beyond it). At a limit, above all of these: compound 1.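

In this assay, iodo in place of ethynyl gives a 1.0-fold lower number from compound 3 to compound 4 (0.01 log units; within the scatter), so at this aromatic carbon a single iodine atom and the two-carbon ethynyl group cannot be told apart. Iodo in place of thiophen-3-yl gives a 2.0-fold lower number from compound 2 to compound 4 (0.31 log units; beyond the scatter), and iodo in place of furan-3-yl gives an at least 3.6-fold lower number from compound 1 to compound 4 (0.56 log units; beyond the scatter), which places both ring-bearing groups at higher numbers than iodo, although compound 3 with its ethynyl group stays within the scatter of compound 2 and so goes against any clean split between ring and non-ring groups. Compound 1 stands at a limit, so the size of its step remains only a floor: the limit of > 20000 nM in this assay, at which 1 of the 4 values shown sits.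

The compounds shown leave open whether another kind of non-ring group on this carbon, such as an amine, a carboxylic acid or a longer alkyl chain, would move the number away from the level shared by compound 3 and compound 4. Also open, going by these compounds, is whether a phenyl ring here would track the thiophen-3-yl group of compound 2, and whether these steps would hold on any core other than the shared one.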